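Trioxolane amides: clearance notes toward compound 3

The compounds below may be only part of what the source reports. "The series", "measured", "known", "first", "only" and "open" are said of these compounds alone.

Compound 1 `NC(=O)CNC(=O)C[C@H]1CC[C@]2(CC1)OO[C@]1(O2)C2CC3CC(C2)CC1C3` and compound 2 `NC(=O)CNC(=O)C[C@@H]1CCC[C@]2(C1)OOC1(O2)C2CC3CC(C2)CC1C3` are the two members measured in an ADME assay on microsomes from liver (Mus musculus) for metabolic stability; on this read-out lower numbers stand for slow clearance and higher numbers for fast clearance. Compound 1 gives 5.6 uL/min. Compound 2 gives 18.6 uL/min, the higher of the two numbers, and the gap to compound 1 is beyond the usual scatter. Compound 3 `NC1CCN(C(=O)C[C@@H]2CCC[C@]3(C2)OOC2(O3)C3CC4CC(C3)CC2C4)CC1` is unmeasured; it differs from compound 2 by 4-aminopiperidin-1-yl in place of (carbamoylmethyl)amino on a carbonyl carbon. For the measured compounds named here, no comparable step has been measured in this assay, so the expected size of the change is uncertain; a shift of about the scatter, tending upward, seems most plausible. The step from compound 2 to compound 3 is expected to be a 1.2-fold higher number from compound 2 to compound 3 (0.07 log units; within the scatter). Compound 3 is estimated at 22 uL/min, within a range of 9 uL/min to 50 uL/min.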

Compound 3, intrinsic clearance in a liver preparation (reported as CLH), per the amount of preparation that the assay uses: 8.2 uL/min
Beside the measured number, compound 3's estimate is 2.7-fold (0.43 log units) above it; the whole stated range lies above it.
By their numbers in this assay, from the lowest: compounds 1 and 3 (each within the scatter of the next); then compound 2.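

At the carbonyl carbon, 4-aminopiperidin-1-yl in place of (carbamoylmethyl)amino gives a 2.3-fold lower number from compound 2 to compound 3 (0.36 log units; beyond the scatter) in this assay. For the compounds shown here, this is the first step measured at this place, and it shows that the read-out responds to the group there, in the direction of slower clearance. Nothing measured accounts for the change.

On these data alone, whether the step follows the ring or its amino group stays open; plain piperidin-1-yl or morpholin-4-yl at the same carbonyl carbon would separate the two. As far as these compounds go, whether the same change holds on the core of compound 1 is also open.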